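The source may hold more compounds than are shown below. What is called first, only, known or untested is meant among the compounds shown, and "the series" means these compounds.

Compound 2 `COc1ccc(/C=C\C(=O)O)c(OCc2cn(-c3ccc(CO)cc3)nn2)c1CC=C(C)C` sets the reference point here. In a functional assay on COLO 205 cells (Homo sapiens) for cytotoxicity, read by MTT assay, with a stated time of 24 h (a lower number here means a stronger inhibitor, a higher number a weaker inhibitor), compound 2 gives 19300 nM, the lowest of the two numbers available, though its neighbour compound 3 `COc1ccc(/C=C\C(=O)O)c(OCc2cn(-c3ccc(NC(=O)c4ccccc4)cc3)nn2)c1CC=C(C)C` gives 20300 nM, and the step of a 1.1-fold higher number from compound 2 to compound 3 (0.02 log units; within the scatter) lies within the scatter, so the two cannot be told apart. In this assay compound 1 `COc1ccc(/C=C\C(=O)O)c(OCc2cn(-c3ccccc3I)nn2)c1CC=C(C)C` gives "not determined" (no result reported), so no result is reported for it and it offers nothing to compare.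

Compound 4 `COc1ccc(/C=C\C(=O)O)c(OCc2cn(-c3ccccc3F)nn2)c1CC=C(C)C` differs from compound 2 by 2-fluorophenyl in place of 4-(hydroxymethyl)phenyl on an aromatic nitrogen. Within the data shown here, the only measured step, from compound 2 to compound 3, exchanged one substituent on the same kind of aromatic ring for another and produced no change beyond the scatter. Nothing measured addresses a 2-fluorophenyl group or the loss of the hydroxymethyl donor and acceptor, so the expectation rests on that single flat step: no movement beyond the scatter in either direction.

Compound 4 is therefore expected to give about 20000 nM, within a range of 8000 nM to 50000 nM, which means an expected step of a 1.0-fold higher number from compound 2 to compound 4 (0.02 log units; within the scatter).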

Compound 4, half-maximal inhibitory concentration: 14500 nM
The estimate for compound 4 lay 1.4-fold (0.14 log units) above the measured number; low and high end bracket the measured number.
By their numbers in this assay, from the lowest: compounds 4, 2 and 3 (each within the scatter of the next).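

In this assay, the step from 4-(hydroxymethyl)phenyl to 2-fluorophenyl on the aromatic nitrogen is a 1.3-fold lower number from compound 2 to compound 4 (0.12 log units; within the scatter), so the two compounds cannot be told apart. This change goes further than the earlier comparison of compound 2 with compound 3: the entering group has 0 hydrogen-bond donors and 0 hydrogen-bond acceptors, whereas the leaving group has 1 of each, and the ring also carries fluorine instead of a hydroxymethyl group. No supporting measurement is available to explain this result.

The compounds shown leave open whether any group at this position can move the number beyond the scatter. A basic amine on the aromatic ring, or a longer alkyl chain in place of that ring, would test this more sharply.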